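A few compounds are considered here, and "the series" means these few. Any claim that something is new, unique, unknown or untested is made for them only; others in the source may bear on it.

Values in an ADME assay on CHO cells (Cricetulus griseus) for cytotoxicity, read by MTT assay; on this read-out higher numbers stand for lower toxicity in this test and lower numbers for higher toxicity in this test:
- Compound 1 `CN1CCC(N2CCN(c3nccc4[nH]c(-c5ccc(F)c(F)c5)nc34)CC2)CC1`: 33000 nM
- Compound 2 `CN1CCN(CC2CCN(c3nccc4[nH]c(-c5ccc(F)c(Cl)c5)nc34)CC2)CC1`: 850 nM

Compound 2 holds the lower of the two numbers, 850 nM, which means higher toxicity in this test. Compound 1 gives 33000 nM, a higher number by a gap that lies beyond the scatter. Compound 3 `CN1CCN(CC2CCN(c3nccc4[nH]c(-c5cccc(C(=O)O)c5)nc34)CC2)CC1` has 3-carboxyphenyl in place of 3-chloro-4-fluorophenyl on an aromatic carbon. Going by the values given here, no measured pair shows this change, so the expectation is a loose one. A rise beyond the scatter is expected in this assay, a 9.4-fold higher number from compound 2 to compound 3 (0.97 log units; beyond the scatter). The estimated value for compound 3 is 8000 nM, with an expected range from 1800 nM to 40000 nM.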

Compound 3, half-maximal cytotoxic concentration: > 50000 nM
Compound 3 ended at the assay's limit; the forecaster's own chance of this, stated with the estimate: 25%; middle value at least 6.2-fold (0.79 log units) away from the limit.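

Compounds 1 and 2 differ in more than one place, so they could not show what this position does on its own. In this assay, putting 3-carboxyphenyl in place of 3-chloro-4-fluorophenyl on this carbon, between two ring nitrogen atoms, gives an at least 58-fold higher number from compound 2 to compound 3 (1.76 log units; beyond the scatter), so this one change is enough to shift the read-out towards lower toxicity in this test. The reading for compound 3 is a limit of the assay, not a number: the limit of > 50000 nM in this assay, at which 1 of the 3 values shown sits.

As far as these compounds go, it remains open whether the step comes from gaining the carboxylic acid or from losing the chlorine and fluorine. A primary amide or a plain phenyl at this place would help separate the two.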